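From Trifluoromethyl to Nitro on the Shared Core

This account rests on a few compounds, and the source may have more. Where it says the series, first, only, none or still open, it means among the compounds named here.

Of the compounds shown here, two on a shared core have been measured in a functional assay on A2780 cells (Homo sapiens) for inhibition, with a stated time of 72 h; a lower number here means a stronger inhibitor, a higher number a weaker inhibitor. Compound 1 `CC1(C)CCOc2ccc(NC(=S)Nc3ccc(OC(F)(F)F)cc3)cc21` carries a trifluoromethoxy group on an aromatic carbon, and in this assay compound 1 gives 4300 nM. Compound 2 `CC1(C)CCOc2ccc(NC(=S)Nc3ccc(C(F)(F)F)cc3)cc21` carries trifluoromethyl on that aromatic carbon instead, and in this assay compound 2 gives 5500 nM. The step of a 1.3-fold higher number from compound 1 to compound 2 (0.11 log units; within the scatter) is the only one available, and it lies within the scatter, so compound 2 stands at the higher of the two numbers with compound 1 close beside it, and no order between them can be claimed.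

Compound 3 `CC1(C)CCOc2ccc(NC(=S)Nc3ccc([N+](=O)[O-])cc3)cc21` is the next member: nitro in place of trifluoromethyl on an aromatic carbon. For the measured compounds named here, no measured step exchanges trifluoromethyl for nitro, so the only guidance is the exchange of one substituent for another on that aromatic carbon, a 1.3-fold higher number from compound 1 to compound 2 (0.11 log units; within the scatter), which moved the number only within the scatter. On that basis a step of no more than the usual scatter is expected in this assay, with no direction favoured; the expected step is a 1.1-fold lower number from compound 2 to compound 3 (0.04 log units; within the scatter). Compound 3 is therefore estimated at 5000 nM, within a range from 2000 nM to 15000 nM.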

Compound 3, half-maximal inhibitory concentration: 6400 nM
Beside the measured number, compound 3's estimate is 1.3-fold (0.11 log units) below it, and the stated range covers the measured number.
By their numbers in this assay, from the lowest: compounds 1, 2 and 3 (each within the scatter of the next).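

Replacing trifluoromethyl with nitro, on an aromatic carbon of a six-membered aromatic ring of carbon only and para to a large group, gives a 1.2-fold higher number from compound 2 to compound 3 (0.07 log units; within the scatter) in this assay, and replacing trifluoromethoxy with nitro at the same place gives a 1.5-fold higher number from compound 1 to compound 3 (0.17 log units; within the scatter). Until now this position had been compared only across two fluorine-bearing groups, whereas nitro brings nitrogen and oxygen in place of carbon and fluorine, along with hydrogen-bond acceptors that trifluoromethyl lacks, and the three compounds still cannot be separated in this assay. No accompanying measurement bears on why these exchanges leave the numbers so close together.

The three groups shown therefore mark out only a small part of what this position could carry, and the compounds leave open whether an amine, a carboxylic acid or a longer alkyl chain on the same aromatic carbon would move the number beyond the scatter. They also leave open whether any group at this position could bring the shared core to a clearly different number in this assay, since every step seen so far stays within the scatter.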